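A Bromo-methoxyphenyl Group Enters in Place of Ethylphenyl

The source may report more compounds than this note shows. Statements on the series, on what has been measured and on what is new or still open speak of the compounds shown alone.

Of the compounds shown here, three sharing one core have been measured in a functional assay on NCI-H226 cells (Homo sapiens) for inhibition, read by MTT assay, with a stated time of 48 h, tested at 10 uM; a lower number here means less inhibition, a higher number more inhibition at the concentration tested (going by the name of the read-out). Compound 1 `COc1ccc(Br)cc1Nc1cc(NC(=O)Nc2c(Cl)cccc2Cl)ncn1` gives 33%, compound 2 `CCc1ccc(Nc2cc(NC(=O)Nc3c(Cl)cccc3Cl)ncn2)cc1` gives 39.5%, and compound 3 `CCc1cccc(Nc2cc(NC(=O)Nc3cc(OC)cc(OC)c3)ncn2)c1` gives 36.7%. Of these three numbers compound 3 holds the second highest, but its gap to compound 2 and its gap to compound 1 both lie within the scatter, so no order among them can be read.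

Compound 4 `COc1cc(NC(=O)Nc2cc(Nc3ccc(Br)cc3OC)ncn2)cc(OC)c1` differs from compound 3 in one place: 4-bromo-2-methoxyphenyl in place of 3-ethylphenyl on a nitrogen on an aromatic ring. Within the data shown here, the one measured step that bears on this, a number 6.5 percentage points higher from compound 1 to compound 2 (within the scatter), exchanged a bromo-methoxyphenyl for an ethylphenyl on the same nitrogen and stayed within the scatter. Among the measured compounds shown here, the present change runs the other way, with a differently substituted pair of groups, and no step from compound 3 to compound 4 has been measured. He therefore expects a step in this assay no larger than the scatter, estimated at a number 3.7 percentage points lower from compound 3 to compound 4 (within the scatter). Compound 4 is accordingly expected to give 33%, with a range from 18% to 48%.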

Compound 4, a percentage reported as inhibition, at one concentration (the size of the read-out at that concentration, not a potency): 25.7%
Compound 4: the middle estimate sits 7.3 percentage points above what was measured; measured number inside the range.
By their numbers in this assay, from the lowest: compounds 4, 1, 3 and 2 (each within the scatter of the next, the first and the last beyond it).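

In this assay the exchange on this nitrogen gives a number 11 percentage points lower from compound 3 to compound 4 (beyond the scatter), whereas the earlier exchange at the same place, a number 6.5 percentage points higher from compound 1 to compound 2 (within the scatter), did not leave the scatter. The group held on this nitrogen can therefore shift the read-out on this core, and 4-bromo-2-methoxyphenyl in place of 3-ethylphenyl shifts it downward, though the step is modest and rests on a single pair of compounds. Nothing available here accounts for this step.

Left open is whether the step belongs to the bromine, to the methoxy group or to the loss of the ethyl group, since all of these change at once in this exchange. From the compounds shown here alone, it also remains open how a phenyl ring carrying an amine such as morpholine, or a carboxylic acid, would read at this nitrogen.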